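The source may report more compounds than this note shows. Statements on the series, on what has been measured and on what is new or still open speak of the compounds shown alone.

Compound 1 `O=C(O)CCc1ccc(OCc2nc(-c3ccccc3Cl)no2)cc1` gives 1200 nM in a functional assay on CHO cells for agonist activity at Free fatty acid receptor 1 (Homo sapiens), read by FLIPR and calcium flux, in the presence of a further agent that is not named here; a higher number here means that more compound is needed for the effect, a lower number that less compound is needed. Compound 2 `Cc1cc(-c2noc(COc3ccc(CCC(=O)O)cc3)n2)ccc1F` gives 2120 nM in this assay.

Compound 2 has the highest of these two numbers; its nearest neighbour is compound 1, and the step of a 1.8-fold higher number from compound 1 to compound 2 (0.25 log units; within the scatter) lies within the scatter. Compound 3 `Cc1ccc(-c2noc(COc3ccc(CCC(=O)O)cc3)n2)cc1` has not been measured. It differs from compound 2 by 4-methylphenyl in place of 4-fluoro-3-methylphenyl on an aromatic carbon. Among the measured compounds shown here, the only measured step that bears on this change is a 1.8-fold higher number from compound 1 to compound 2 (0.25 log units; within the scatter), a swap of the same aryl group that moved the number very little. The step from compound 2 to compound 3 is therefore expected to be a 1.1-fold lower number from compound 2 to compound 3 (0.03 log units; within the scatter), no shift beyond the scatter. Compound 3 is estimated at 2000 nM, between 800 nM and 5000 nM.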

Compound 3, half-maximal effective concentration: 300 nM
Compound 3: the middle estimate sits 6.7-fold (0.82 log units) above what was measured; the measured number lies below the stated range.
By their numbers in this assay, from the lowest: compound 3; then compounds 1 and 2 (each within the scatter of the next).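

On an aromatic carbon of the five-membered ring, the choice of aryl group proves to matter: 4-methylphenyl in place of 4-fluoro-3-methylphenyl gives a 7.1-fold lower number from compound 2 to compound 3 (0.85 log units; beyond the scatter) in this assay and, in place of 2-chlorophenyl, gives a 4.0-fold lower number from compound 1 to compound 3 (0.60 log units; beyond the scatter). Among the compounds shown here, the earlier swap between the other two aryl groups had stayed within the scatter, so these are the first steps at this position to go beyond it. Nothing available accounts for this shift.

The compounds shown leave open how a plain phenyl, a 3-methylphenyl or a 4-ethylphenyl would behave here. They also leave open whether the gain with 4-methylphenyl would persist with a longer chain carrying the carboxylic acid.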